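Replacing the fluorophenyl of a thiosemicarbazone with pyrrolyl

The compounds below may be only part of what the source reports. "The series", "measured", "known", "first", "only" and "open" are said of these compounds alone.

Compound 1 `CC1=CC[C@H](C(C)(C)NC(=S)N/N=C/c2ccccc2)CC1` gives 8700 nM.
Compound 2 `CC1=CC[C@H](C(C)(C)NC(=S)N/N=C/c2ccc(O)cc2)CC1` gives > 100000 nM, which is a limit of the assay.
Compound 3 `CC1=CC[C@H](C(C)(C)NC(=S)N/N=C/c2ccc(F)cc2)CC1` gives > 100000 nM, which is a limit of the assay.

In a functional assay on OVCAR-3 cells (Homo sapiens) for inhibition, read by sulforhodamine B assay, with a stated time of 48 h (on this read-out lower numbers stand for stronger inhibition of growth and higher numbers for weaker inhibition of growth), compound 3 sits only at a limit, so its number is not known; it shares that position with compound 2, as the limit of > 100000 nM in this assay, at which 2 of the 3 values shown sit, records. Compound 4 `CC1=CC[C@H](C(C)(C)NC(=S)N/N=C/c2ccc[nH]2)CC1` differs from compound 3 in one place: 1H-pyrrol-2-yl in place of 4-fluorophenyl on a carbon with a double bond to nitrogen. Among the measured steps, the ones that bear on this change are the two that start from the unsubstituted phenyl of compound 1: an at least 11-fold higher number from compound 1 to compound 3 (1.06 log units; beyond the scatter) and an at least 11-fold higher number from compound 1 to compound 2 (1.06 log units; beyond the scatter). Both were large and in the same direction, while a step that the two limits leave unreadable from compound 2 to compound 3 cannot be read, as both ends are limits. Going by the values given here, compound 4 carries no substituent on its ring, which brings it closer to compound 1 than to compound 3 in that respect, but the ring itself is different, and no measured compound shows what a five-membered ring does here. Compound 4 is therefore expected to lie somewhere between the value of compound 1 and the limit at which compound 3 sits, with an at least 2.5-fold lower number from compound 3 to compound 4 (0.39 log units; beyond the scatter) as the expected step. The estimate for compound 4 in this assay is 40000 nM, with a range from 8000 nM to 150000 nM.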

Compound 4, concentration for 50% growth inhibition: 33500 nM
Compound 4: middle estimate off by 1.2-fold (0.08 log units), on the high side; the measured number falls inside the stated range.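

In this assay, going by these compounds alone, 1H-pyrrol-2-yl is the first replacement at this position that gives a readable number besides the phenyl of compound 1, with an at least 2.9-fold lower number from compound 3 to compound 4 (0.47 log units; beyond the scatter) and an at least 2.9-fold lower number from compound 2 to compound 4 (0.47 log units; beyond the scatter). It does not fully match the unsubstituted phenyl, however, with a 3.9-fold higher number from compound 1 to compound 4 (0.59 log units; beyond the scatter), so compound 1 keeps the lowest number among the four compounds. Exchanging the phenyl for this five-membered ring therefore costs less in this assay than placing a hydroxy or fluoro group on the phenyl, as compound 2 and compound 3 both remain at the limit: the limit of > 100000 nM in this assay, at which 2 of the 4 values shown sit.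

The ring size, the ring nitrogen and the hydrogen-bond donor all change together in compound 4, so the compounds shown cannot separate their contributions, and the step between the two limits cannot be read. Going by these compounds, whether a furanyl or pyridinyl ring at this carbon would behave like 1H-pyrrol-2-yl, and whether a methyl group or an amine on the pyrrole would move the number toward that of compound 1, remains open.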